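A few compounds are considered here, and "the series" means these few. Any claim that something is new, unique, unknown or untested is made for them only; others in the source may bear on it.

Measured compounds:
- compound 1, `COc1ccc(C2=NN(C3=NC(=O)/C(=C4\C(=O)Nc5ccc(Br)cc54)S3)C(c3ccc(OC)cc3)C2)cc1`: 62700 nM
- compound 2, `COc1ccc(C2CC(c3ccc4ccccc4c3)=NN2C2=NC(=O)/C(=C3\C(=O)Nc4ccc(Br)cc43)S2)cc1`: 3370 nM
- compound 3, `COc1ccc(C2=NN(C3=NC(=O)/C(=C4\C(=O)Nc5ccccc54)S3)C(c3ccc(Cl)cc3)C2)cc1`: 90900 nM

The three measured compounds were tested in a functional assay on cells (Leukemia cell, Homo sapiens) for cytotoxicity, read by sulforhodamine B assay, with a stated time of 48 h; a higher number here means a weaker inhibitor of growth, a lower number a stronger inhibitor of growth. Compound 1 gives 62700 nM in this assay, compound 2 gives 3370 nM, and compound 3 gives 90900 nM. Compound 1 and compound 3 sit within the usual scatter of each other, so no order between them can be read from these numbers. Compound 2 stands apart from both as the strongest inhibitor of growth of the set. The step of a 19-fold lower number from compound 1 to compound 2 (1.27 log units; beyond the scatter) is large and rests on one change: naphthalen-2-yl in place of 4-methoxyphenyl on a carbon with a double bond to nitrogen.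

Compound 4, `O=C1N=C(N2N=C(c3ccc4ccccc4c3)CC2c2ccc(Cl)cc2)S/C1=C1/C(=O)Nc2ccccc21`, has not yet been measured in this assay. It is related to compound 3 by naphthalen-2-yl in place of 4-methoxyphenyl on a carbon with a double bond to nitrogen. This is the same kind of change as that from compound 1 to compound 2, but not the same: in compound 1 the ring atom two ring bonds away bears a 4-methoxyphenyl group, whereas in compound 3 that ring atom bears a 4-chlorophenyl group. The difference between the cores of compound 1 and compound 3 is not broken down here.

For compound 4 a step of roughly that size is expected, an 18-fold lower number from compound 3 to compound 4 (1.26 log units; beyond the scatter), because the same kind of change produced a 19-fold lower number from compound 1 to compound 2 (1.27 log units; beyond the scatter). Among the compounds with values here, on that basis compound 4 is estimated at 5000 nM in this assay, with a plausible range from 1500 nM to 16000 nM, the width reflecting that only one earlier instance of this change is available.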

Compound 4, concentration for total growth inhibition: 71600 nM
Estimate against measurement, compound 4: 14-fold (1.16 log units) below; the whole stated range lies below it.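

In this assay, placing naphthalen-2-yl in place of 4-methoxyphenyl on the carbon with a double bond to nitrogen gives a 1.3-fold lower number from compound 3 to compound 4 (0.10 log units; within the scatter), so on this core the change has no effect that can be read from the data. The large step seen on the other core therefore did not carry over, and the two steps differ clearly: the same change on two cores in this assay, a 19-fold lower number (1.27 log units; beyond the scatter) from compound 1 to compound 2 and a 1.3-fold lower number (0.10 log units; within the scatter) from compound 3 to compound 4, 15-fold (1.17 log units) apart, beyond the scatter of two such steps This shows that, in this series, the size of the step depends on the core that carries the change, but with one pair on each core it does not show which feature of the cores matters, nor whether the 4-chlorophenyl group plays any part, since the core of compound 1 and the core of compound 3 are not separated into single changes here.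

The compounds shown leave open how the same change would behave on a core that differs from either of these in one place only, such as one keeping the 4-chlorophenyl group while adding the bromine seen in compound 1. They also leave open whether other groups on that carbon, such as a pyridine ring or a morpholine-bearing phenyl ring, would follow either step.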